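Adding a second methoxy to compound 3

A few compounds are considered here, and "the series" means these few. Any claim that something is new, unique, unknown or untested is made for them only; others in the source may bear on it.

Three compounds have numbers in a functional assay on ZR-75-1 cells (Homo sapiens) for inhibition, read by sulforhodamine B assay (on this read-out higher numbers stand for weaker inhibition of growth and lower numbers for stronger inhibition of growth), so far. Compound 1 `c1ccc(-c2ccc(-c3ccc(-c4nc5ccccc5[nH]4)cc3)cc2)cc1` reads 100000 nM and compound 3 `COc1ccc(-c2ccc(-c3ccc(-c4nc5ccccc5[nH]4)cc3)cc2)cc1` reads 35100 nM while compound 2 `COc1ccc(-c2ccc(-c3ccc(-c4nc5cc(C)ccc5[nH]4)cc3)cc2)cc1OC` reads 3100 nM on the same scale. Compound 3 thus holds the middle place of the three numbers.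

One change leads from compound 3 to compound 4 `COc1ccc(-c2ccc(-c3ccc(-c4nc5ccccc5[nH]4)cc3)cc2)cc1OC` in this series. The change methoxy in place of hydrogen on an aromatic carbon turns 4-methoxyphenyl into 3,4-dimethoxyphenyl, with the new methoxy ortho to a methoxy group and meta to a large group.

For the measured compounds named here, the one measured step of this kind is a 2.8-fold lower number from compound 1 to compound 3 (0.45 log units; beyond the scatter) for methoxy in place of hydrogen on an aromatic carbon, a modest step beyond the scatter. Going by the values given here, compound 2 also carries the 3,4-dimethoxyphenyl group and reads lower than compound 3, but it differs from compound 4 elsewhere in the core and so gives no clean step. Going by a 2.8-fold lower number from compound 1 to compound 3 (0.45 log units; beyond the scatter) as the guide, a step of similar modest size toward a lower number is expected, though one within the scatter cannot be ruled out. The expected change is a 2.7-fold lower number from compound 3 to compound 4 (0.43 log units; beyond the scatter) on this reasoning. Compound 4 is estimated at 13000 nM with an expected range of 4000 nM to 35000 nM in this assay once measured.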

Compound 4, concentration for 50% growth inhibition: 39700 nM
Compound 4: the middle estimate sits 3.1-fold (0.48 log units) below what was measured; the whole stated range lies below it.
By their numbers in this assay, from the lowest: compound 2; then compounds 3 and 4 (each within the scatter of the next); then compound 1.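

In this assay, the second methoxy that turns 4-methoxyphenyl into 3,4-dimethoxyphenyl gives no readable change, a 1.1-fold higher number from compound 3 to compound 4 (0.05 log units; within the scatter), so the step seen for the first methoxy does not repeat at this carbon, ortho to a methoxy group and meta to a large group. For the compounds shown here, the overall step from the unsubstituted phenyl, a 2.5-fold lower number from compound 1 to compound 4 (0.40 log units; beyond the scatter), stays modest, and the single methoxy of compound 3 already accounts for a step of that size. With 3,4-dimethoxyphenyl held constant, the methyl on the shared core goes with a large step, a 13-fold higher number from compound 2 to compound 4 (1.11 log units; beyond the scatter), so the low number of compound 2 goes with that methyl and not with the second methoxy. Nothing available explains why the second methoxy leaves the number flat or why the methyl step is so large.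

Going by these compounds, whether the methyl on the core gives a step of similar size when paired with 4-methoxyphenyl or with plain phenyl remains open. Also open, on these data alone, is how a hydroxy, an amine or a carboxylic acid in place of the second methoxy would read on this scale.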